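The source may hold more compounds than are shown below. What is called first, only, known or untested is meant among the compounds shown, and "the series" means these compounds.

Compound 1, `CN(C)C(=O)c1cc2cnc(Nc3ccc(NC(=O)C4(C(=O)Nc5cccc(O)c5)CC4)cc3)nc2n1C1CCCC1`, stands second highest of the three numbers in a functional assay on T47D cells (Homo sapiens) for inhibition, read by CCK-8 assay, with a stated time of 72 h, tested at 10 uM (a higher number here means more inhibition of growth at the concentration tested, a lower number less inhibition of growth), where compound 1 gives 83.7%. Compound 3, `CN(C)C(=O)c1cc2cnc(Nc3ccc(NC(=O)C4(C(=O)Nc5ccc(O)cc5)CC4)cc3)nc2n1C1CCCC1`, gives 95.8%, while compound 2, `CN(C)C(=O)c1cc2cnc(Nc3ccc(NC(=O)C4(C(=O)Nc5ccc(Cl)c(C(F)(F)F)c5)CC4)cc3)nc2n1C1CCCC1`, gives 55.8%. The move to compound 4, `CN(C)C(=O)c1cc2cnc(Nc3ccc(NC(=O)C4(C(=O)Nc5ccccc5)CC4)cc3)nc2n1C1CCCC1`, is hydrogen in place of hydroxy on an aromatic carbon. Within the data shown here, no measured step simply removes the hydroxy. The nearest guides are a number 12.1 percentage points higher from compound 1 to compound 3 (beyond the scatter), a number 27.9 percentage points lower from compound 1 to compound 2 (beyond the scatter) and a number 40 percentage points higher from compound 2 to compound 3 (beyond the scatter); both compounds carrying a hydroxy sit beyond the scatter above the one without. On that basis a modest loss of growth inhibition is expected for compound 4, a number 13.7 percentage points lower from compound 1 to compound 4 (beyond the scatter). The estimate for compound 4 is 70%, within a range from 50% to 88%.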

Compound 4, percent growth inhibition at one concentration: 93.9%
The estimate for compound 4 lay 23.9 percentage points below the measured number, outside the stated range (above it).
By their numbers in this assay, from the lowest: compound 2; then compound 1; then compounds 4 and 3 (each within the scatter of the next).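

In this assay, the hydroxy proves unnecessary for growth inhibition at this ring: removing it gives a number 10.2 percentage points higher from compound 1 to compound 4 (beyond the scatter) and a number 1.9 percentage points lower from compound 3 to compound 4 (within the scatter) for the two hydroxy isomers. The plain phenyl also keeps the large advantage over the ring carrying chloro and trifluoromethyl, with a number 38.1 percentage points higher from compound 2 to compound 4 (beyond the scatter) as the step. Nothing measured here gives a reason for these differences. Still open, on these data alone, is how a methoxy or an amine on this ring would compare, and whether chloro or trifluoromethyl alone accounts for the lower number of compound 2.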